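The source may report more compounds than this note shows. Statements on the series, on what has been measured and on what is new or still open speak of the compounds shown alone.

In a functional assay on HT-29 cells (Homo sapiens) for cytotoxicity, read by sulforhodamine B assay (a higher number here means that more compound is tolerated, a lower number that less compound is tolerated), compound 1 `CC1=CC[C@@H]([C@@](C)(O)CCCC(C)(C)NC(=S)N/N=C\c2ccc([N+](=O)[O-])cc2)CC1` gives > 100000 nM, which is a limit of the assay and not a number. Going by the values given here, compound 2 `CC1=CC[C@@H]([C@@](C)(O)CCCC(C)(C)NC(=S)N/N=C\c2cccc(Cl)c2)CC1` gives 45900 nM, the only true number so far. Next is compound 3 `CC1=CC[C@@H]([C@@](C)(O)CCCC(C)(C)NC(=S)N/N=C\c2ccc(Cl)cc2)CC1`, and the change is 4-chlorophenyl in place of 3-chlorophenyl on a carbon with a double bond to nitrogen. Among the compounds with values here, one measured step bears on it, at the same place: an at least 2.1-fold lower number from compound 1 to compound 2 (0.33 log units; beyond the scatter), with 3-chlorophenyl in place of 4-nitrophenyl. That step has only a lower bound on its size and replaces a different group, so it gives no size for the change from 3-chlorophenyl to 4-chlorophenyl alone. No step beyond the scatter is therefore expected in this assay. The estimated change is a 1.1-fold higher number from compound 2 to compound 3 (0.04 log units; within the scatter). For compound 3 the expected value is 50000 nM, with an estimated range from 20000 nM to 100000 nM.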

Compound 3, concentration lethal to 50% of the cells: 47300 nM
The estimate for compound 3 lay 1.1-fold (0.02 log units) above the measured number, and the stated range covers the measured number.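

In this assay, 4-chlorophenyl in place of 3-chlorophenyl on the carbon with a double bond to nitrogen gives a 1.0-fold higher number from compound 2 to compound 3 (0.01 log units; within the scatter), so the two chlorophenyl groups cannot be told apart here. Chloro in place of nitro on an aromatic carbon gives an at least 2.1-fold lower number from compound 1 to compound 3 (0.32 log units; beyond the scatter), the first step in the series that changes only that one group on the ring. As far as these compounds go, compound 1 gives a limit and not a number, so the full size of that step stays unknown: the limit of > 100000 nM in this assay, at which 1 of the 3 values shown sits.

From the compounds shown here alone, whether another group on the aromatic ring, such as an amine or a carboxylic acid, would shift the number beyond the scatter stays open. Also open, going by these compounds, is how the number responds to a change elsewhere on the shared core, such as a shorter chain.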